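The source may report more compounds than this note shows. Statements on the series, on what has been measured and on what is new or still open speak of the compounds shown alone.

The measured compounds:

compound 1, `CCn1c(SCC(=O)Nc2ccc(/C(C)=N/O)cc2)nnc1-c1ccc(OC)c(OC)c1`, 65%
compound 2, `COc1ccc(-c2nnc(SCC(=O)Nc3ccc(/C(C)=N/O)cc3)n2-c2ccccc2)cc1`, 56%
compound 3, `CCn1c(SCC(=O)Nc2ccc(/C(C)=N/O)cc2)nnc1-c1cc(OC)c(OC)c(OC)c1`, 49%

All three were tested in a functional assay on the whole organism (strain albino) for inhibition, with Rattus norvegicus as the target, read by paw edema, with stated times of 30 min and 2 h, at a dose of 0.28 mmol/kg by the oral route; a lower number here means less inhibition, a higher number more inhibition at the dose given (going by the name of the read-out). Compound 1 and compound 3 share a core and differ by one change, (methoxy in place of hydrogen on an aromatic carbon), and this change gave the step of a number 16 percentage points lower from compound 1 to compound 3 (beyond the scatter). Compound 2 rests on a different core; how its core differs from that of compound 1 is not broken down here. Against compound 3 the value of compound 2 lies within the scatter, as does its gap to compound 1, so no order among them can be read from these numbers.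

Compound 4, `COc1ccc(-c2nnc(SCC(=O)Nc3ccc(/C(C)=N/O)cc3)n2-c2ccccc2)cc1OC`, has not yet been measured. It differs from compound 2 by methoxy in place of hydrogen on an aromatic carbon. Among the measured compounds shown here, this is the same kind of change as the one from compound 1 to compound 3, though there the entering methoxy is also meta to a methoxy group, while in compound 4 it is not. For the measured compounds named here, because the earlier change gave a number 16 percentage points lower from compound 1 to compound 3 (beyond the scatter), a step of similar direction is expected, a number 12 percentage points lower from compound 2 to compound 4 (beyond the scatter), with wide uncertainty since only one example exists. Compound 4 is therefore estimated at 44%, between 30% and 58%.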

Compound 4, a percentage reported as inhibition, in the whole organism at one dose (the size of the read-out at that dose, not a potency): 63%
Beside the measured number, compound 4's estimate is 19 percentage points below it; measured number above the stated range.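

In this assay, methoxy in place of hydrogen, read here as 4-methoxyphenyl to 3,4-dimethoxyphenyl, gave a number 7 percentage points higher from compound 2 to compound 4 (within the scatter), and the change did not behave alike on the two cores: the same change on two cores in this assay, a number 16 percentage points lower (beyond the scatter) from compound 1 to compound 3 and a number 7 percentage points higher (within the scatter) from compound 2 to compound 4, 23 percentage points apart, beyond the scatter of two such steps

This shows that the step seen on the core of compound 1 cannot simply be carried to the core of compound 2. It does not show what sets the two apart, as each core offers a single pair and the ring taking the methoxy already carries a different set of groups in each, so the core and the place of entry cannot be separated. Phenyl in place of ethyl on the aromatic nitrogen gave a number 2 percentage points lower from compound 1 to compound 4 (within the scatter), so these two compounds cannot be ordered.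

On these data alone, whether a further methoxy on the dimethoxyphenyl ring of compound 4 would lower the number, as on the core of compound 1, remains open. So does the effect on the read-out of a hydroxy group or a chlorine on that ring, or of a longer chain such as butyl on the aromatic nitrogen.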